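Oxanyl amine series: dropping the methylene from compound 3

The source may hold more compounds than are shown below. What is called first, only, known or untested is meant among the compounds shown, and "the series" means these compounds.

In a functional assay on cells for antagonist activity at C-X-C chemokine receptor type 4 (Homo sapiens), read by fluorescence and calcium flux, with stated times of 25 min and 90 s (a higher number here means a weaker inhibitor, a lower number a stronger inhibitor), compound 3 `c1ccc2c(c1)CN[C@@H](CN(CCCCNCC1CCOCC1)[C@H]1CCCc3cccnc31)C2` gives 52.9 nM, the lowest of the three numbers. Compound 2 `c1ccc2c(c1)CN[C@@H](CN(CCCCNCC1CCCCC1)[C@H]1CCCc3cccnc31)C2` gives 158 nM, and compound 1 `c1cncc(CN(CCCCN(C[C@H]2Cc3ccccc3CN2)[C@H]2CCCc3cccnc32)Cc2cccnc2)c1` gives 471 nM. Among the measured compounds shown here, the only single-point step measured, a 3.0-fold lower number from compound 2 to compound 3 (0.48 log units; beyond the scatter), swaps the ring on the chain carbon bound to the amine nitrogen. For the measured compounds named here, compound 4 `c1ccc2c(c1)CN[C@@H](CN(CCCCNC1CCOCC1)[C@H]1CCCc3cccnc31)C2` differs from compound 3 by oxan-4-yl in place of (oxan-4-yl)methyl on an amine nitrogen, shortening the link rather than changing the ring, and no measured step bears directly on that change. Compound 4 is therefore expected to stay close to compound 3, with a 1.6-fold higher number from compound 3 to compound 4 (0.21 log units; within the scatter) most likely within the scatter or a modest weakening. The estimate for compound 4 in this assay is 85 nM, with a range of 30 nM to 260 nM.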

Compound 4, half-maximal inhibitory concentration: 29.4 nM
Compound 4: the middle estimate sits 2.9-fold (0.46 log units) above what was measured; measured number below the stated range.
By their numbers in this assay, from the lowest: compounds 4 and 3 (each within the scatter of the next); then compound 2; then compound 1.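

In this assay, the methylene on the amine nitrogen is not needed at this position: a 1.8-fold lower number from compound 3 to compound 4 (0.26 log units; within the scatter), so oxan-4-yl and (oxan-4-yl)methyl cannot be told apart. Against the carbocyclic side chain, the ring with its oxygen keeps its advantage with the shorter link, with a 5.4-fold lower number from compound 2 to compound 4 (0.73 log units; beyond the scatter). No supporting data bear on why either step reads as it does.

Still open, from the compounds shown here alone, is how cyclohexyl directly on the amine nitrogen would read in this assay. Going by these compounds, a longer link, such as 2-(oxan-4-yl)ethyl, also remains open.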